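Cyclohexyl in place of isopropyl on a fluorobenzyl urea

This account rests on a few compounds, and the source may have more. Where it says the series, first, only, none or still open, it means among the compounds named here.

Compound 1 `CC(C)NC(=O)N1CCN(C(=S)SCc2cn(Cc3ccccc3F)nn2)CC1`: 7130 nM
Compound 2 `O=C(NC1CCCCC1)N1CCN(C(=S)SCc2cn(Cc3ccccc3F)nn2)CC1`: > 128000 nM
Compound 3 `CC(C)NC(=O)N1CCN(C(=S)SCc2cn(Cc3ccc(F)cc3)nn2)CC1`: 5970 nM

In a functional assay on SMMC-7721 cells (Homo sapiens) for cytotoxicity, read by MTT assay, with a stated time of 72 h (on this read-out higher numbers stand for weaker inhibition and lower numbers for stronger inhibition), compound 3 gives 5970 nM, and compound 1 sits within the scatter of it, as a 1.2-fold lower number from compound 1 to compound 3 (0.08 log units; within the scatter) shows. For compound 2 the assay reports only a limit, (the limit of > 128000 nM in this assay, at which 1 of the 3 values shown sits). Compound 4 `O=C(NC1CCCCC1)N1CCN(C(=S)SCc2cn(Cc3ccc(F)cc3)nn2)CC1` differs from compound 3 by cyclohexyl in place of isopropyl on an amide-type nitrogen. The same change has been measured once, from compound 1 to compound 2, where it gave an at least 17-fold higher number from compound 1 to compound 2 (1.25 log units; beyond the scatter), a large weakening. A step of similar size is therefore expected here, a 25-fold higher number from compound 3 to compound 4 (1.40 log units; beyond the scatter), and the assay may again report only a limit. Compound 4 is estimated at 150000 nM, with a range from 40000 nM to 500000 nM.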

Compound 4, half-maximal inhibitory concentration: > 128000 nM
Compound 4: only a limit was reported; the forecaster's own chance of this, stated with the estimate: 65%; the middle value is on the limit's open side.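

In this assay the value of compound 4 is a limit, > 128000 nM and not an exact number. Cyclohexyl in place of isopropyl gives an at least 21-fold higher number from compound 3 to compound 4 (1.33 log units; beyond the scatter), so the large weakening seen with the 2-fluorophenyl group also appears with the 4-fluorophenyl group: the same change on two cores in this assay, an at least 17-fold higher number (1.25 log units; beyond the scatter) from compound 1 to compound 2 and an at least 21-fold higher number (1.33 log units; beyond the scatter) from compound 3 to compound 4; the limit leaves it open whether they differ. The step from compound 2 to compound 4 cannot be read, as both values are limits. The compounds shown leave open how far the true values lie past the limit, and whether cyclopropyl, cyclopentyl or phenyl on that nitrogen would stay near the isopropyl compounds.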